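The source may hold more compounds than are shown below. What is called first, only, known or untested is meant among the compounds shown, and "the series" means these compounds.

Compound 1, `CC/C=C\C(=O)Nc1cc(Nc2nccc(-c3cn(C)c4ccc(F)cc34)n2)c(OC)cc1N(C)CCN(C)C`, gives 5290 nM.
Compound 2, `C=CC(=O)Nc1cc(Nc2ncc(C#N)c(-c3cn(C)c4ccc(F)cc34)n2)c(OC)cc1N(C)CCN(C)C`, gives 17500 nM.

Both numbers come from a functional assay on HepG2 cells (Homo sapiens) for antiproliferative activity, read by MTT assay, with a stated time of 72 h; on this read-out higher numbers stand for weaker inhibition and lower numbers for stronger inhibition. Within the data shown here, compound 2 stands at the highest of the two, meaning the weaker inhibition; the only other compound, compound 1, sits at a lower number, and that gap lies beyond the usual scatter of this assay. Compound 1 and compound 2 differ in more than one place, so their two values show only that, not what any single change does.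

Compound 3 is `CC/C=C\C(=O)Nc1cc(Nc2ncc(C#N)c(-c3cn(C)c4ccc(F)cc34)n2)c(OC)cc1N(C)CCN(C)C`. It differs from compound 2 in one place: but-1-en-1-yl in place of vinyl on a carbonyl carbon. Among the measured compounds shown here, no measured pair isolates this change, so there is nothing to rest a firm step on. The expectation is a step of a 1.5-fold lower number from compound 2 to compound 3 (0.16 log units; within the scatter) in this assay, modest in size and not certain to lie beyond the scatter. On that basis, compound 3 is estimated at 12000 nM, within a range from 4000 nM to 36000 nM.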

Compound 3, half-maximal inhibitory concentration: 5880 nM
Estimate against measurement, compound 3: 2.0-fold (0.31 log units) above; the measured number falls inside the stated range.
By their numbers in this assay, from the lowest: compounds 1 and 3 (each within the scatter of the next); then compound 2.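

Among these compounds, on the carbonyl carbon, the size of the group counts in this assay: putting but-1-en-1-yl in place of vinyl gives a 3.0-fold lower number from compound 2 to compound 3 (0.47 log units; beyond the scatter), the first single change here to be read beyond the scatter. On an aromatic carbon, cyano in place of hydrogen gives a 1.1-fold higher number from compound 1 to compound 3 (0.05 log units; within the scatter), so with but-1-en-1-yl on the carbonyl carbon this second change shows no difference that can be told from the scatter. Nothing shown gives a reason for either result.

From the compounds shown here alone, both steps rest on a single pair each, so it remains open whether the change from vinyl to but-1-en-1-yl gives a similar step when the aromatic carbon bears hydrogen rather than cyano. Going by these compounds, how a saturated butyl group or a dimethylaminomethyl-bearing vinyl group would read on that carbonyl carbon also remains open.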